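The compounds below may be only part of what the source reports. "The series", "measured", "known", "first", "only" and "open" are said of these compounds alone.

Working notes on the series. All four compounds share one core, differing only in the aryl ring attached through the thiourea. Compound 1 `CNC(=O)c1ccc(Oc2cccc(NC(=S)Nc3ccc(F)cc3)c2)nc1` carries a 4-fluorophenyl group there, and in a functional assay on PC-3 cells (Homo sapiens) for antiproliferative activity, read by MTT assay (a lower number here means a stronger inhibitor, a higher number a weaker inhibitor), compound 1 gives 32700 nM. Compound 2 `CNC(=O)c1ccc(Oc2cccc(NC(=S)Nc3cc(C(F)(F)F)cc(C(F)(F)F)c3)c2)nc1` gives 5860 nM in this assay. Compound 3 `CNC(=O)c1ccc(Oc2cccc(NC(=S)Nc3ccc(OC(F)(F)F)cc3)c2)nc1` returns only a limit of the assay in this assay, > 100000 nM. Among the two actual numbers compound 1 stands as the higher one, with compound 2 the lower.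

Compound 4 `CNC(=O)c1ccc(Oc2cccc(NC(=S)Nc3ccc(F)c(Cl)c3)c2)nc1` differs from compound 1 by chloro in place of hydrogen on an aromatic carbon. Among the compounds with values here, the single measured step, an at least 3.0-fold higher number from compound 1 to compound 3 (0.48 log units; beyond the scatter), replaces the fluoro itself rather than adding a chloro next to it, so it bears only loosely on this change; compound 3 in that step sits at the limit of > 100000 nM in this assay, at which 1 of the 3 values shown sits. Within the data shown here, no measured pair adds a halogen while keeping the fluoro. With that thin support, a step of a 1.8-fold lower number from compound 1 to compound 4 (0.26 log units; within the scatter) is expected, direction uncertain and likely within the scatter. Compound 4 is estimated at 18000 nM in this assay, plausibly between 5000 nM and 70000 nM.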

Compound 4, half-maximal inhibitory concentration: 18400 nM
For compound 4 the middle estimate is 1.0-fold (0.01 log units) below the measured one; measured number inside the range.
By their numbers in this assay, from the lowest: compound 2; then compounds 4 and 1 (each within the scatter of the next). At a limit, above all of these: compound 3.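

In this assay, chloro ortho to the fluoro group gives a 1.8-fold lower number from compound 1 to compound 4 (0.25 log units; within the scatter), so the 3-chloro-4-fluorophenyl group cannot be told apart from the 4-fluorophenyl group of the parent. Within the data shown here, this is the first view of a change that keeps the fluoro group in place, and it shows that a chloro can enter at this aromatic carbon without a shift beyond the scatter. Nothing shown here gives a cause for this step.

From the compounds shown here alone, whether an amine, a methoxy or a carboxylic acid at this same carbon would also leave the number within the scatter remains open. Also open, going by these compounds, is how a chloro at this carbon would read with hydrogen in place of the fluoro, as in a 3-chlorophenyl group.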